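The compounds below may be only part of what the source reports. "The series", "measured", "known", "first", "only" and "open" are said of these compounds alone.

In a functional assay on the whole organism with Rattus norvegicus as the target (a higher number here means that more compound is needed for the effect, a lower number that less compound is needed), compound 3 `N=c1sc2cc(OC(F)(F)F)ccc2n1CCS(N)(=O)=O` gives 6 mg/kg and compound 1 `CCn1c(=N)sc2cc(OC(F)(F)F)ccc21` gives 5 mg/kg so the two sit level within the scatter (a 1.2-fold higher number from compound 1 to compound 3 (0.08 log units; within the scatter)). Compound 2 `N=c1sc2cc(OC(F)(F)F)ccc2n1Cc1ccccc1` reads > 10 mg/kg as a limit of the assay and not a number.

Compound 4 `CSCn1c(=N)sc2cc(OC(F)(F)F)ccc21` alters the chain of compound 3: methylsulfanyl in place of sulfamoylmethyl on a saturated chain carbon bound to an aromatic nitrogen with methylsulfanyl in place of sulfamoylmethyl on a saturated chain carbon bound to an aromatic nitrogen.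

The step that bears most directly on this change is the one that adds sulfamoyl to the chain (a 1.2-fold higher number from compound 1 to compound 3 (0.08 log units; within the scatter)), and it stays within the scatter. The two steps involving compound 2 (an at least 2.0-fold higher number from compound 1 to compound 2 (0.30 log units; that floor lies within the scatter)) and (an at least 1.6-fold lower number from compound 2 to compound 3 (0.22 log units; that floor lies within the scatter)) rest on its limit, and their floors also lie within the scatter, so they fix no size. Compound 1 and compound 3 both carry a chain with no ring, as compound 4 does, and that shared feature is the closest guide available, though it rests on only these two measured compounds. No step beyond the scatter is therefore expected, and no direction is favoured: the estimated step is (a 1.2-fold lower number from compound 3 to compound 4 (0.08 log units; within the scatter)).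

For compound 4 the expected value in this assay is 5 mg/kg with an estimated range from 2 mg/kg to 12 mg/kg.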

Compound 4, dose for half-maximal effect: 3 mg/kg
Compound 4: middle estimate off by 1.7-fold (0.22 log units), on the high side, within the range that was stated.
By their numbers in this assay, from the lowest: compounds 4, 1 and 3 (each within the scatter of the next). At a limit, above all of these: compound 2.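

In this assay, compound 4 adds a third open chain at the saturated chain carbon bound to an aromatic nitrogen, and it stays level with the other two: a 2.0-fold lower number from compound 3 to compound 4 (0.30 log units; within the scatter) and a 1.7-fold lower number from compound 1 to compound 4 (0.22 log units; within the scatter), so methylsulfanyl, sulfamoylmethyl and methyl are not told apart at this position. Going by these compounds alone, the one step here that clears the scatter is an at least 3.3-fold lower number from compound 2 to compound 4 (0.52 log units; beyond the scatter), methylsulfanyl in place of phenyl, so the position does respond to a change, although the steps from compound 2 to compound 3 and from compound 1 to compound 2 go against any general split between phenyl and open chains, as their floors remain within the scatter. Compound 2 reads as a limit and not a number, so this step gives a floor and no exact size: the limit of > 10 mg/kg in this assay, at which 1 of the 4 values shown sits.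

The compounds shown leave open whether an amine or a carboxylic acid at the end of a longer chain would stay level with compound 1, compound 3 and compound 4 in this assay. They also leave open whether a pyridyl group in place of phenyl would read like compound 2 or like the open chains.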